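The compounds below may be only part of what the source reports. "The series", "measured", "known", "first", "only" and "open" are said of these compounds alone.

Compounds measured so far:
compound 1 `Cc1c(Cl)cccc1N1C(=N)S/C(=C\c2ccc(OCc3ccccc3)cc2)C1=O`, 59.7%
compound 2 `N=C1S/C(=C\c2ccc(OCc3ccccc3)cc2)C(=O)N1c1ccccn1`, 37.2%

In an ADME assay on RAW264.7 cells (Mus musculus) for cytotoxicity, read by MTT assay, with a stated time of 48 h, tested at 50 uM (a lower number here means less inhibition, a higher number more inhibition at the concentration tested (going by the name of the read-out)), compound 1 gives 59.7%. Compound 2 gives 37.2% in this assay, the lowest of the two numbers available; its nearest neighbour is compound 1, reached by the step of a number 22.5 percentage points lower from compound 1 to compound 2 (beyond the scatter), which swaps the whole aryl group on the amide-type nitrogen of the ring.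

Compound 3 `Cc1cccc(N2C(=N)S/C(=C\c3ccc(OCc4ccccc4)cc3)C2=O)n1` has not yet been measured. It differs from compound 2 in one place: methyl in place of hydrogen on an aromatic carbon. Going by the values given here, no measured step adds a methyl to an aromatic carbon, so the one step recorded, a number 22.5 percentage points lower from compound 1 to compound 2 (beyond the scatter), bears on the present case only loosely, as a sign that changes at this aryl group can move this assay beyond the scatter. A single methyl is a far smaller change than that aryl swap, and nothing in the data shows its effect.

Compound 3 is therefore expected to stay close to compound 2, with a step of a number 4.8 percentage points higher from compound 2 to compound 3 (within the scatter) that remains within the scatter. The estimate for compound 3 in this assay is 42%, within the range 25% to 60%.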

Compound 3, a percentage reported as inhibition, at one concentration (the size of the read-out at that concentration, not a potency): 25.1%
Estimate against measurement, compound 3: 16.9 percentage points above; measured number inside the range.
By their numbers in this assay, from the lowest: compound 3; then compound 2; then compound 1.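

In this assay, the step of a number 12.1 percentage points lower from compound 2 to compound 3 (beyond the scatter) shows that a single methyl on an aromatic carbon next to the ring nitrogen can move this number beyond the scatter, something the earlier whole-group exchange could not show for so small a change. Measured against the same 3-chloro-2-methylphenyl compound, 6-methylpyridin-2-yl gives the step of a number 34.6 percentage points lower from compound 1 to compound 3 (beyond the scatter), which is graded large, whereas pyridin-2-yl gave the modest step of a number 22.5 percentage points lower from compound 1 to compound 2 (beyond the scatter) in the same comparison. No independent measurement accompanies these numbers to say what lies behind the effect of the methyl.

The compounds shown leave open whether the lower number is particular to methyl or would also appear with a chlorine, a methoxy group or an amine on the same carbon. They also leave open whether a methyl elsewhere on the ring, or a longer chain such as ethyl at this carbon, would lower the number further, leave it within the scatter of compound 2 or raise it.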